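Hydroxy in Place of Nitro: Dose Expected to Stay Put

The source may hold more compounds than are shown below. What is called first, only, known or untested is meant among the compounds shown, and "the series" means these compounds.

Measured compounds:
- compound 1 `C=C(C)[C@@H]1CC=C(C)/C(=N/NC(=O)Nc2nnc(-c3ccc(Cl)cc3)o2)C1`, in a functional assay on the whole organism (strain Wistar) with Rattus norvegicus as the target, with a stated time of 4 h (on this read-out higher numbers stand for an effect only at larger amounts of compound and lower numbers for an effect already at smaller amounts), compound 1 gives 300 mg/kg
- compound 2 `COc1ccc(-c2nnc(NC(=O)N/N=C/C/C(C)=C\CC=C(C)C)o2)cc1`, compound 2 gives 300 mg/kg
- compound 3 `CC(C)=CC/C=C(/C)C/C=N/NC(=O)Nc1nnc(-c2ccc([N+](=O)[O-])cc2)o1`, compound 3 gives 300 mg/kg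

Compound 3 stands level with compounds 1 and 2 in this assay: all three were effective at the same dose, and none of the gaps between them goes beyond the usual scatter of repeated measurements. Within the data shown here, the one step among the measured compounds that changes a single group, nitro in place of methoxy on an aromatic carbon, shows no change at the digits printed from compound 2 to compound 3 (within the scatter).

Compound 4 `CC(C)=CC/C=C(/C)C/C=N/NC(=O)Nc1nnc(-c2ccc(O)cc2)o1` differs from compound 3 by hydroxy in place of nitro on an aromatic carbon, which a bond further out reads as 4-nitrophenyl to 4-hydroxyphenyl. Among the measured compounds shown here, the only comparable information is the methoxy-to-nitro step on the same aromatic carbon, which left the dose unchanged. On that basis, compound 4 is expected to show no change at the digits printed from compound 3 to compound 4 (within the scatter), a step that stays within the scatter. Compound 4 is therefore estimated at 300 mg/kg, with a range from 150 mg/kg to 600 mg/kg.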

Compound 4, minimum effective dose: 300 mg/kg
Compound 4: middle estimate and measured number agree at the digits printed; low and high end bracket the measured number.
By their numbers in this assay, from the lowest: compounds 1, 2, 3 and 4 (each within the scatter of the next).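

In this assay, putting hydroxy in place of nitro on the aromatic carbon para to a large group gives no change at the digits printed from compound 3 to compound 4 (within the scatter) and so adds a second single-group change at this position to the earlier one. Hydrogen in place of methyl on the same oxygen gives no change at the digits printed from compound 2 to compound 4 (within the scatter) as well, so methoxy, nitro and hydroxy now stand level here across compounds 2, 3 and 4. The hydroxy brings a hydrogen-bond donor that neither nitro nor methoxy has, and the read-out does not separate it from either group.

On these data alone, whether an amine or a carboxylic acid at this position would also leave the dose level remains open. Nothing measured here explains why these three groups read the same.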